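A Smaller Side Group on the Aromatic Ring of Compound 3

The compounds below may be only part of what the source reports. "The series", "measured", "known", "first", "only" and "open" are said of these compounds alone.

Compound 3, `C/N=C(/N)c1cccc(C2Oc3ccccc3N(CCCCCN3C(C)CCCC3C)C2=O)c1`, gives the highest number of the three measured compounds in an assay on isolated protein for inhibition of serine protease 1 (Homo sapiens), tested at 100 uM; a higher number here means more inhibition at the concentration tested (going by the name of the read-out), a lower number less inhibition: compound 3 gives 32%. Compound 1, `CC1CCCC(C)N1CCCCCN1C(=O)C(c2ccccc2)Oc2ccccc21`, gives 2.8% in this assay, and compound 2, `COc1ccc(C2Oc3ccccc3N(CCCCCN3C(C)CCCC3C)C2=O)cc1OC`, gives 0%. The step of a number 29.2 percentage points higher from compound 1 to compound 3 (beyond the scatter) shows that the group added to the aromatic ring carries most of the inhibition seen, and the step of a number 32 percentage points higher from compound 2 to compound 3 (beyond the scatter) points the same way, while a number 2.8 percentage points lower from compound 1 to compound 2 (within the scatter) stays within the scatter.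

Compound 4, `CC1CCCC(C)N1CCCCCN1C(=O)C(c2cccc(C(=N)S)c2)Oc2ccccc21`, alters exactly that group: a group of 3 heavy atoms (1 carbon, 1 nitrogen, 1 sulfur; no ring) in place of a group of 4 heavy atoms (2 carbon, 2 nitrogen; no ring), on an aromatic carbon. Within the data shown here, no measured step tests this particular replacement. Among the measured compounds shown here, what is known is only that leaving the aromatic ring without such a group, as in compound 1, gives far less inhibition than compound 3. Because the new group is smaller and differs in its atoms from the one that brought the gain in a number 29.2 percentage points higher from compound 1 to compound 3 (beyond the scatter), the expectation for compound 4 is a fall in this assay, a number 17 percentage points lower from compound 3 to compound 4 (beyond the scatter), though its size is uncertain. Compound 4 is therefore estimated at 15%, with a likely range from 0% to 35%.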

Compound 4, a percentage reported as inhibition, at one concentration (the size of the read-out at that concentration, not a potency): 5.2%
The estimate for compound 4 lay 9.8 percentage points above the measured number, within the range that was stated.
By their numbers in this assay, from the lowest: compounds 2, 1 and 4 (each within the scatter of the next); then compound 3.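

At this aromatic carbon, meta to a large group, the swap of side groups in this assay gives a number 26.8 percentage points lower from compound 3 to compound 4 (beyond the scatter) and so shows that the inhibition of compound 3 does not follow from having just any small group with a double bond and a nitrogen here. Set against the bare phenyl ring, the new group gives a number 2.4 percentage points higher from compound 1 to compound 4 (within the scatter) and, set against the 3,4-dimethoxyphenyl group, it gives a number 5.2 percentage points higher from compound 2 to compound 4 (within the scatter) so compound 4 cannot be told apart from either compound. Among these compounds, the earlier compounds showed only that a group at this carbon could raise the number, whereas this result shows that the gain depends on which group stands there, and nothing measured here explains the difference between the two groups.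

Still open, on these data alone, is whether an amine or a carboxylic acid on this aromatic carbon would match compound 3 or fall back to the level of compound 4. As far as these compounds go, it is equally open whether a longer chain carrying the side group of compound 3 would keep, raise or lose its inhibition in this assay.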